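This account rests on a few compounds, and the source may have more. Where it says the series, first, only, none or still open, it means among the compounds named here.

Measured compounds, with values in a functional assay on CHO-K1 cells for antagonist activity at cysteinyl leukotriene receptor 1 (Homo sapiens), read by fluorescence and calcium flux, with stated times of 30 min and 1 h; on this read-out lower numbers stand for stronger inhibition and higher numbers for weaker inhibition: compound 1 `Cc1c(F)cccc1CCCCOc1ccc(/C=C/c2cccc3c(CCCC(=O)O)cn(CC(=O)O)c23)cc1` gives 2.9 nM; compound 2 `O=C(O)CCCc1cn(CC(=O)O)c2c(/C=C/c3ccc(OCCCCOc4ccccc4)cc3)cccc12` gives 1.5 nM; compound 3 `Cc1c(CCCC(=O)O)c2cccc(/C=C/c3ccc(OCCCCc4c(F)ccc(F)c4F)cc3)c2n1CC(=O)O` gives 2.4 nM.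

Compound 3 stands second highest of the three numbers, within the scatter of both compound 1 and compound 2. The next compound, compound 4 `O=C(O)CCCc1cn(CC(=O)O)c2c(/C=C/c3ccc(OCCCCc4c(F)ccc(F)c4F)cc3)cccc12`, differs from compound 3 by hydrogen in place of methyl on an aromatic carbon. Going by the values given here, no measured step touches this position: the only step in hand, a 1.9-fold lower number from compound 1 to compound 2 (0.29 log units; within the scatter), concerns the chain end and is itself within the scatter. Compound 1 and compound 2 already carry hydrogen at the place in question and sit in the same range as compound 3. Compound 4 is therefore expected to show no step beyond the scatter, a 1.0-fold higher number from compound 3 to compound 4 (0.02 log units; within the scatter). The estimate for compound 4 is 2.5 nM, between 0.9 nM and 7 nM.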

Compound 4, half-maximal inhibitory concentration in the cysteinyl leukotriene receptor 1 assay: 1 nM
For compound 4 the middle estimate is 2.5-fold (0.40 log units) above the measured one, within the range that was stated.
By their numbers in the cysteinyl leukotriene receptor 1 assay, from the lowest: compounds 4, 2, 3 and 1 (each within the scatter of the next, the first and the last beyond it).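

In the cysteinyl leukotriene receptor 1 assay this position, on an aromatic carbon next to the ring nitrogen, gives a step beyond the scatter for one atom exchanged: a 2.4-fold lower number from compound 3 to compound 4 (0.38 log units; beyond the scatter). With the same core, changes at the chain end read a 1.5-fold lower number from compound 2 to compound 4 (0.18 log units; within the scatter) and a 2.9-fold lower number from compound 1 to compound 4 (0.46 log units; beyond the scatter). The same exchange also shows in a physicochemical assay for permeability, using PAMPA, with a stated time of 4 h, at pH 7.4, tested at 50 uM (on this read-out lower numbers stand for lower permeability and higher numbers for higher permeability), where compound 3 gives 2.6 10^-6 cm/s. In the physicochemical assay compound 4 gives < 0.05 10^-6 cm/s, which is a limit of the assay and not a number. The two read together as follows: the measured apparent permeability of compound 3, 2.6 10^-6 cm/s, and of compound 4, < 0.05 10^-6 cm/s, an at least 52-fold lower number (1.71 log units; beyond the scatter)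

Open, on these data alone, is how ethyl, chlorine or an amine at this position would read in either assay. Open too, as far as these compounds go, is whether methyl there gives similar steps with the phenoxy chain end of compound 2.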